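From methylamino to butylamino: one more chain step

This account rests on a few compounds, and the source may have more. Where it says the series, first, only, none or still open, it means among the compounds named here.

In an ADME assay on HaCaT cells (Homo sapiens) for cytotoxicity, read by MTT assay, with a stated time of 72 h (on this read-out higher numbers stand for weaker inhibition and lower numbers for stronger inhibition), compound 1 (`CC(C)(C)C1=CC(=O)C=CC1=O`) gives 95000 nM and compound 2 (`CCNC1=CC(=O)C(C(C)(C)C)=CC1=O`) gives 75000 nM on the same read-out. Compound 3 (`CNC1=CC(=O)C(C(C)(C)C)=CC1=O`) gives 28000 nM and so holds the lowest number of the three. Compound 4 (`CCCCNC1=CC(=O)C(C(C)(C)C)=CC1=O`) carries propyl in place of hydrogen on a saturated chain carbon bound to an amine nitrogen, which turns methylamino into butylamino.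

The nearest guide is the shorter chain change, a 2.7-fold lower number from compound 2 to compound 3 (0.43 log units; beyond the scatter) in this assay when methyl is removed. Read in reverse, it points to a higher number as the chain grows. The other two steps set the background: a 3.4-fold lower number from compound 1 to compound 3 (0.53 log units; beyond the scatter) for methylamino, and a 1.3-fold lower number from compound 1 to compound 2 (0.10 log units; within the scatter) for ethylamino. For the measured compounds named here, with only one chain pair to go on, a modest rise is expected rather than a large one. The expected change is a 2.1-fold higher number from compound 3 to compound 4 (0.33 log units; beyond the scatter) by this estimate. For compound 4 the estimated value is 60000 nM with an expected range of 25000 nM to 130000 nM in this assay for now.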

Compound 4, half-maximal inhibitory concentration: > 100000 nM
Compound 4: only a limit was reported (the forecaster's own chance of this, stated with the estimate: 5%); middle value at least 1.6-fold (0.22 log units) away from the limit.
By their numbers in this assay, from the lowest: compound 3; then compounds 2 and 1 (each within the scatter of the next). At a limit, above all of these: compound 4.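

Compound 4 gives no number in this assay, only a limit of the assay, so everything read from it is a floor: the limit of > 100000 nM in this assay, at which 1 of the 4 values shown sits. Even so, an at least 3.5-fold higher number from compound 3 to compound 4 (0.55 log units; beyond the scatter) shows that lengthening methylamino to butylamino moves the read-out clearly away from the lowest number, so the earlier gain of methylamino does not return with the longer chain. The other two floors, an at least 1.3-fold higher number from compound 2 to compound 4 (0.12 log units; that floor lies within the scatter) and an at least 1.0-fold higher number from compound 1 to compound 4 (0.02 log units; that floor lies within the scatter), lie within the scatter, so the limit does not set butylamino clear of ethylamino or of hydrogen at this position.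

On these data alone, how far the true value of compound 4 lies past its limit remains open, so the size of the change from ethylamino to butylamino cannot be told. Also open, as far as these compounds go, is how a propylamino chain, a branched isopropylamino chain or a chain ending in a hydroxyl group would read at this position.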